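Swapping a Five-Membered Ring for a Six-Membered One

The source may hold more compounds than are shown below. What is called first, only, known or untested is meant among the compounds shown, and "the series" means these compounds.

Compound 1 `c1cc(OC2CCCC2)ccc1NC1=NCCO1` and compound 2 `c1cc(OC2CCCCC2)ccc1NC1=NCCO1` share one core and differ only in the group on the oxygen. In a functional assay on M21 cells (Homo sapiens) for inhibition, read by sulforhodamine B assay, with a stated time of 48 h (a higher number here means a weaker inhibitor of growth, a lower number a stronger inhibitor of growth), compound 1 gives 21100 nM, and compound 2 gives 20800 nM. The change cyclohexyl in place of cyclopentyl on an oxygen on an aromatic ring thus made a 1.0-fold lower number from compound 1 to compound 2 (0.01 log units; within the scatter). Compound 3 `O=C(CCl)NC(=O)Nc1ccc(OC2CCCC2)cc1` carries a different core; how it differs from the core of compound 1 is not broken down here. In this assay compound 3 gives 2900 nM, the lowest of the three numbers. Compound 4 `O=C(CCl)NC(=O)Nc1ccc(OC2CCCCC2)cc1` differs from compound 3 by cyclohexyl in place of cyclopentyl on an oxygen on an aromatic ring, the same change seen between compound 1 and compound 2. Because the earlier change made a 1.0-fold lower number from compound 1 to compound 2 (0.01 log units; within the scatter), the expected step is no change at the digits printed from compound 3 to compound 4 (within the scatter). The estimate for compound 4 in this assay is 2900 nM, with a likely range from 1400 nM to 6000 nM.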

Compound 4, concentration for 50% growth inhibition: 5000 nM
Compound 4: middle estimate off by 1.7-fold (0.24 log units), on the low side; low and high end bracket the measured number.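

The swap of cyclopentyl for cyclohexyl gives a 1.7-fold higher number from compound 3 to compound 4 (0.24 log units; within the scatter) in this assay and so carries over between these two cores with no step beyond the scatter: the same change on two cores in this assay, a 1.0-fold lower number (0.01 log units; within the scatter) from compound 1 to compound 2 and a 1.7-fold higher number (0.24 log units; within the scatter) from compound 3 to compound 4, 1.7-fold (0.24 log units) apart, within the scatter of two such steps.

Changing the group on the nitrogen while cyclohexyl stays in place gives a 4.2-fold lower number from compound 2 to compound 4 (0.62 log units; beyond the scatter) and so moves the number more than the ring swap does. This does not show that the swap would stay as quiet on a third core.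

The compounds shown leave open how a cyclobutyl ring, a phenyl ring or a longer chain on the oxygen would read in this assay on either core.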